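The source may hold more compounds than are shown below. What is called first, only, known or untested is meant among the compounds shown, and "the series" means these compounds.

The measured compounds:
compound 1 `COc1ccc(-c2nc(C)c(C(=O)CSc3nc(N)c(C#N)c(-c4ccccc4)n3)s2)cc1` gives 57.8%
compound 2 `Cc1nc(-c2ccccc2)sc1C(=O)CSc1nc(N)c(C#N)c(-c2ccc(Cl)cc2)n1` gives 58.8%

Both numbers come from a functional assay on U-87MG ATCC cells for antiproliferative activity against U-87 MG (Homo sapiens), read by MTT assay, with a stated time of 48 h, tested at 10 uM; on this read-out lower numbers stand for a stronger effect and higher numbers for a weaker effect at the one concentration tested. In this assay compound 2 gives 58.8%, the higher of the two numbers shown, and compound 1 gives 57.8%, a number lower by an amount that lies within the scatter of repeated measurements, so the two values show no difference that can be read as an order. Compound 3 `Cc1nc(-c2ccccc2)sc1C(=O)CSc1nc(N)c(C#N)c(-c2ccccc2)n1` has not yet been measured in this assay. It differs from compound 2 in one place: hydrogen in place of chloro on an aromatic carbon. Going by the values given here, nothing among the measured compounds shows the effect of this change, since the two measured compounds differ from each other at more than one place and no step between them is available. With no evidence pointing either way, the step from compound 2 to compound 3 is expected to be a number 0.8 percentage points lower from compound 2 to compound 3 (within the scatter), that is, no change beyond the scatter. Compound 3 is therefore estimated to give 58% in this assay, with a range from 45% to 72%.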

Compound 3, a percentage reported as activity, at one concentration (the size of the read-out at that concentration, not a potency): 93%
Estimate against measurement, compound 3: 35 percentage points below; measured number above the stated range.
By their numbers in this assay, from the lowest: compounds 1 and 2 (each within the scatter of the next); then compound 3.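

In this assay, going by these compounds alone, the step of a number 34.2 percentage points higher from compound 2 to compound 3 (beyond the scatter) shows that the chloro of the 4-chlorophenyl group is not interchangeable with hydrogen at this place: on this aromatic carbon, para to a large group, hydrogen goes with a clearly weaker effect at the one concentration tested, which the earlier compounds could not reveal. The step of a number 35.2 percentage points higher from compound 1 to compound 3 (beyond the scatter) shows the same direction for hydrogen in place of methoxy, at a different place in the molecule, so compound 3, which carries neither group, has the weakest effect of the three compounds. Nothing available explains either step.

The compounds shown leave open whether the chloro itself is needed at this place or whether another group there, such as fluoro, methyl or an amine, would go with a similarly strong effect. They also leave open what happens when chloro and methoxy stand on the same molecule, and whether these steps hold at concentrations other than the single one tested.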